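Methyl on the ring nitrogen: a cytotoxicity estimate

A few compounds are considered here, and "the series" means these few. Any claim that something is new, unique, unknown or untested is made for them only; others in the source may bear on it.

Measured compounds in an ADME assay on Vero cells (Chlorocebus sabaeus) for cytotoxicity, read by MTT assay, with a stated time of 48 h; a lower number here means a stronger inhibitor, a higher number a weaker inhibitor:
Compound 1 `CN(Cc1ccc2c(c1)OCCO2)c1nc(=O)c2cc(C(F)(F)F)cc([N+](=O)[O-])c2o1` gives 9.27 ug/mL.
Compound 2 `O=c1nc(NCc2ccccc2)oc2c([N+](=O)[O-])cc(C(F)(F)F)cc12` gives 25.4 ug/mL.
Compound 3 `O=c1nc(NCc2ccc3c(c2)OCCO3)oc2c([N+](=O)[O-])cc(C(F)(F)F)cc12` gives 25.3 ug/mL.

Compound 4 `CN(Cc1ccccc1)c1nc(=O)c2cc(C(F)(F)F)cc([N+](=O)[O-])c2o1` has not yet been measured. It differs from compound 2 by methyl in place of hydrogen on a nitrogen on an aromatic ring. The same change was already made once, from compound 3 to compound 1, where it reads (methyl in place of hydrogen on a nitrogen on an aromatic ring); that step was a 2.7-fold lower number from compound 3 to compound 1 (0.44 log units; beyond the scatter). The cores of compound 2 and compound 3 differ by phenyl in place of 2,3-dihydro-1,4-benzodioxin-6-yl on a saturated chain carbon bound to a nitrogen on an aromatic ring, a change that gave a 1.0-fold lower number from compound 2 to compound 3 (0.00 log units; within the scatter), so the two starting points sit at the same level.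

For compound 4 the expected step is therefore a 2.5-fold lower number from compound 2 to compound 4 (0.40 log units; beyond the scatter), resting on the earlier step of a 2.7-fold lower number from compound 3 to compound 1 (0.44 log units; beyond the scatter) and the value of compound 2, 25.4 ug/mL. Compound 4 is estimated at 10 ug/mL, likely between 5 ug/mL and 20 ug/mL.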

Compound 4, half-maximal inhibitory concentration: 3.84 ug/mL
The estimate for compound 4 lay 2.6-fold (0.42 log units) above the measured number; measured number below the stated range.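

In this assay, the new methyl step, a 6.6-fold lower number from compound 2 to compound 4 (0.82 log units; beyond the scatter), agrees with the earlier methyl step once the scatter of two such steps is allowed for: the same change on two cores in this assay, a 2.7-fold lower number (0.44 log units; beyond the scatter) from compound 3 to compound 1 and a 6.6-fold lower number (0.82 log units; beyond the scatter) from compound 2 to compound 4, 2.4-fold (0.38 log units) apart, within the scatter of two such steps. The change of ring group, read between the two methylated compounds as a 2.4-fold lower number from compound 1 to compound 4 (0.38 log units; beyond the scatter), likewise does not separate from the same change between the two compounds without the methyl: the same change on two cores in this assay, a 1.0-fold lower number (0.00 log units; within the scatter) from compound 2 to compound 3 and a 2.4-fold higher number (0.38 log units; beyond the scatter) from compound 4 to compound 1, 2.4-fold (0.38 log units) apart, within the scatter of two such steps. The methyl change therefore went the same way on both cores, but two pairs cannot fix a single size for the step or show that it would hold on any other core.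

The compounds shown leave open what an ethyl group or a longer chain would do in place of the methyl. They also leave open whether the step survives with an amine or a carboxylic acid on the phenyl ring.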